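Swapping Fluoro for a ((2-carboxyethyl)carbonyl)amino Chain

The source may report more compounds than this note shows. Statements on the series, on what has been measured and on what is new or still open speak of the compounds shown alone.

Measured so far in an ADME assay on Vero cells (Chlorocebus sabaeus) for cytotoxicity; on this read-out lower numbers stand for higher toxicity in this test and higher numbers for lower toxicity in this test:
- Compound 1 `O=[N+]([O-])c1ccc(-c2nc3cc(C(F)(F)F)ccc3[nH]2)cc1`: 45000 nM
- Compound 2 `Fc1ccc(-c2nc3cc(C(F)(F)F)ccc3[nH]2)cc1`: 60000 nM

Among the measured compounds shown here, with only two compounds measured, compound 2 cannot be separated from compound 1, and the two stand level in this assay. The difference between them is a 1.3-fold higher number from compound 1 to compound 2 (0.12 log units; within the scatter). Repeat measurements of one compound can differ this much, so the numbers show no real change.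

The next compound is compound 3 `O=C(O)CCC(=O)Nc1ccc(-c2nc3cc(C(F)(F)F)ccc3[nH]2)cc1`. Its change from compound 2 is ((2-carboxyethyl)carbonyl)amino in place of fluoro on an aromatic carbon. In words, ((2-carboxyethyl)carbonyl)amino takes the place of fluoro on an aromatic carbon, para to a large group.

For the measured compounds named here, only one measured step bears on this change, the exchange of nitro for fluoro, a 1.3-fold higher number from compound 1 to compound 2 (0.12 log units; within the scatter). That step gives no sign that this aromatic carbon moves the read-out. However, neither measured compound carries a chain like the incoming one, so this evidence is thin and the range must stay wide.

The expected change is a 1.2-fold higher number from compound 2 to compound 3 (0.07 log units; within the scatter), which means no clear step in either direction. For compound 3 the estimated value is 70000 nM, with an expected range of 30000 nM to 160000 nM.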

Compound 3, half-maximal cytotoxic concentration: > 100000 nM
Compound 3: a limit, no number (the forecaster's own chance of this, stated with the estimate: 30%); at least 1.4-fold (0.15 log units) between middle value and limit.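

Compound 3 reaches a limit of the assay and gives no number, so this assay places it only on one side of that limit: the limit of > 100000 nM in this assay, at which 1 of the 3 values shown sits. Replacing fluoro with the ((2-carboxyethyl)carbonyl)amino chain gives an at least 1.6-fold higher number from compound 2 to compound 3 (0.22 log units; that floor lies within the scatter), and since that floor lies within the scatter, this step alone does not show a real change. Among the compounds shown here, the comparison with the nitro compound goes further, with an at least 2.2-fold higher number from compound 1 to compound 3 (0.34 log units; beyond the scatter), the first step in this set beyond the scatter, showing that an aromatic carbon para to a large group can carry a chain of 8 heavy atoms with no sign of higher toxicity in this test.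

The compounds shown do not tell which part of the chain goes with this result, since a plain amine, an amide without the carboxylic acid, and a longer chain ending in a carboxylic acid would each separate those parts. They also leave open whether the same chain would behave this way on a core other than the one shared by these three compounds.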